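This account rests on a few compounds, and the source may have more. Where it says the series, first, only, none or still open, it means among the compounds named here.

Measured compounds:
- Compound 1, `C=CC1=C(C(=O)NC(C)(C)C)C(c2ccc(OC)cc2)OC1`: in a functional assay on A549 cells (Homo sapiens) for cytotoxicity, read by MTT assay, with a stated time of 24 h (on this read-out lower numbers stand for stronger inhibition and higher numbers for weaker inhibition), compound 1 gives > 100000 nM, which is a limit of the assay and not a measured number.
- Compound 2, `C=CC1=C(C(=O)NCc2ccccc2)C(c2ccc(Cl)c(Cl)c2)OC1`: compound 2 gives > 100000 nM, again a limit rather than a number.
- Compound 3, `C=CC1=C(C(=O)NCCC)C(c2ccc(OC)c(OC)c2)OC1`: compound 3 gives > 100000 nM, also a limit.

Compound 1 therefore cannot be placed on a scale of numbers at all. Every value that has been recorded in this assay sits at the same ceiling, (the limit of > 100000 nM in this assay, at which 3 of the 3 values shown sit), so there is no ordering among compound 1, compound 2 and compound 3, and nothing here separates one of them from another. The three share the same core and differ in the group on the amide nitrogen and in the substituents on the aryl ring, yet none of these changes has brought a compound below the limit.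

Compound 4, `C=CC1=C(C(=O)Nc2ccc(C)cc2)C(c2ccc(OC)cc2)OC1`, is the next compound to be tested. It differs from compound 1 in one place: 4-methylphenyl in place of tert-butyl on an amide-type nitrogen. Within the data shown here, no step between two measured compounds is available to guide the expectation, and nothing in the recorded values suggests that any change of this kind moves the compounds into the measurable range. The step from compound 1 to compound 4 is therefore expected to be none beyond the scatter, a number no higher from compound 1 to compound 4 (the limit leaves the size open), with the compound most likely remaining at the limit. The estimate for compound 4 in this assay is 100000 nM, with a range from 30000 nM to 300000 nM.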

Compound 4, half-maximal inhibitory concentration: > 100000 nM
Compound 4 gave a limit, no number; the forecaster's own chance of this, stated with the estimate: 70%; the middle value sits exactly at the limit.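

Compound 1 and compound 4 both stop at a limit rather than giving a number, so the size of any step between them cannot be read: the limit of > 100000 nM in this assay, at which 4 of the 4 values shown sit.

The compounds shown leave open whether any change to the shared core or its groups would bring a value under this ceiling, and how far beyond it each compound lies.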